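This account rests on a few compounds, and the source may have more. Where it says the series, first, only, none or still open, it means among the compounds named here.

Series notes. Compound 1 `CC(C#Cc1cccc(C(=O)NCc2cccc(F)c2)c1)N(O)C(N)=O`, compound 2 `CC(C)C(C#Cc1cccc(C(=O)NCc2ccccc2C(F)(F)F)c1)N(O)C(N)=O` and compound 3 `C[C@H](C#Cc1cccc(C(=O)NCCC(c2ccc(F)cc2)c2ccc(C(F)(F)F)cc2)c1)N(O)C(N)=O` share one core and differ from one another in more than one part of the molecule. In an assay for inhibition of Polyunsaturated fatty acid 5-lipoxygenase (Homo sapiens), read by HPLC, with stated times of 15 min and 10 min (on this read-out higher numbers stand for weaker inhibition and lower numbers for stronger inhibition), compound 1 gives 4000 nM, compound 2 gives 500 nM and compound 3 gives 220 nM. Compound 3 thus stands at the lowest of the three numbers; compound 2 is nearest to it, with a gap that lies beyond the scatter, and compound 1 is furthest, with a gap also beyond the scatter. No pair among these three differs in a single place, so none of the gaps between compounds 1, 2 and 3 can be assigned to one change.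

Compound 4 `C[C@H](C#Cc1cccc(C(=O)NCCC(c2ccc(F)cc2)c2ccc(OC(F)(F)F)cc2)c1)N(O)C(N)=O` is the next member. It differs from compound 3 in one place: trifluoromethoxy in place of trifluoromethyl on an aromatic carbon. Among the measured compounds shown here, no measured pair shows this change, so the expectation rests on the value of compound 3 alone. The step of a 1.1-fold higher number from compound 3 to compound 4 (0.06 log units; within the scatter) is expected to be small, in either direction, and not beyond the scatter. In this assay compound 4 is expected at 250 nM, within a range from 100 nM to 650 nM.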

Compound 4, half-maximal inhibitory concentration in the Polyunsaturated fatty acid 5-lipoxygenase assay: 260 nM
Compound 4: middle estimate off by 1.0-fold (0.02 log units), on the low side, and the stated range covers the measured number.
By their numbers in the Polyunsaturated fatty acid 5-lipoxygenase assay, from the lowest: compounds 3, 4 and 2 (each within the scatter of the next, the first and the last beyond it); then compound 1.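

In the Polyunsaturated fatty acid 5-lipoxygenase assay, trifluoromethoxy in place of trifluoromethyl on an aromatic carbon, para to a large group, gives a 1.2-fold higher number from compound 3 to compound 4 (0.07 log units; within the scatter), so this position accepts the exchange with no readable change in inhibition. Among the compounds shown here, no pair among compound 1, compound 2 and compound 3 differs in one place, which makes this the first change that can be read on its own. In a physicochemical assay for solubility, at pH 7.4 (on this read-out lower numbers stand for lower solubility and higher numbers for higher solubility), the same exchange does separate the pair, with compound 3 at 3000 nM and compound 4 at 10000 nM, so inhibition and solubility part ways at this position for this one pair: the measured solubility of compound 3, 3000 nM, and of compound 4, 10000 nM, a 3.3-fold higher number (0.52 log units; beyond the scatter)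

Open, from the compounds shown here alone, is whether a methoxy group, a chlorine atom or a carboxylic acid at this same place would also leave the number in the Polyunsaturated fatty acid 5-lipoxygenase assay within the scatter, and whether any of them would move solubility further, since one pair gives no trend. Also open, going by these compounds, is which of the several differences among compound 1, compound 2 and compound 3 carries their gaps, as these differences still cannot be taken apart.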